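This account rests on a few compounds, and the source may have more. Where it says the series, first, only, none or still open, it means among the compounds named here.

Compound 1 `Cc1c(O)ccc2c1[C@H](Cn1cc(-c3ccccc3)nn1)[C@@]13CC(=O)[C@@](C)(CC[C@@H]21)C3` gives > 20000 nM in a functional assay on A549 cells (Homo sapiens) for cytotoxicity, read by MTT assay, with a stated time of 4 days (a higher number here means a weaker inhibitor, a lower number a stronger inhibitor), which is a limit of the assay.
Compound 2 `Cc1ccc(S(=O)(=O)Oc2ccc3c(c2C)[C@H](Cn2cc(-c4ccccc4)nn2)[C@@]24CC(=O)[C@@](C)(CC[C@@H]32)C4)cc1` gives > 20000 nM in this assay, again a limit.
Compound 3 `C=C1C[C@]23C[C@@]1(O)CC[C@@H]2c1cccc(C)c1[C@@H]3Cn1cc(-c2ccccn2)nn1` gives > 20000 nM in this assay, also a limit.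

Compound 2 therefore stands at the limit of this assay, as do the other two, a point summed up by the limit of > 20000 nM in this assay, at which 3 of the 3 values shown sit. Compound 4 `Cc1ccc(S(=O)(=O)Oc2ccc3c(c2C)[C@H](Cn2cc(-c4ccc(C(F)(F)F)cc4)nn2)[C@@]24CC(=O)[C@@](C)(CC[C@@H]32)C4)cc1` differs from compound 2 by trifluoromethyl in place of hydrogen on an aromatic carbon. Going by the values given here, the only measured step, a step that the two limits leave unreadable from compound 1 to compound 2, lies between two limits and cannot be read, and no measured pair touches this part of the molecule. With every value shown sitting at the limit, compound 4 is expected to stay there, and the step that the limit leaves unreadable from compound 2 to compound 4 is estimated as none beyond the scatter. Compound 4 is thus estimated at 30000 nM, within 8000 nM to 120000 nM, most likely reported again only as a limit.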

Compound 4, half-maximal inhibitory concentration: > 20000 nM
Compound 4: no number, only a limit (the forecaster's own chance of this, stated with the estimate: 80%); the middle value lies beyond the limit too.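

Going by these compounds alone, compound 2 and compound 4 both give only a limit in this assay, so no step between them can be read. The compounds shown leave open how any of these changes affects cytotoxicity, as all sit at one limit: the limit of > 20000 nM in this assay, at which 4 of the 4 values shown sit.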